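The compounds below may be only part of what the source reports. "The series", "measured", "known", "first", "only" and "open" are said of these compounds alone.

Compound 3 `C#CCSc1nc(Nc2ccc(F)cc2)c2ccncc2n1` belongs to a small set of three compounds that share one core and differ only in the group attached to a nitrogen on an aromatic ring. In a functional assay on PC-3 cells (Homo sapiens) for inhibition, read by MTT assay, with a stated time of 72 h (a lower number here means a stronger inhibitor, a higher number a weaker inhibitor), compound 3 gives 17300 nM. Compound 2 `C#CCSc1nc(Nc2ccc(C)cc2)c2ccncc2n1` gives 15700 nM in this assay, and the two numbers sit within the usual scatter of each other, as a 1.1-fold higher number from compound 2 to compound 3 (0.04 log units; within the scatter) shows. Compound 1 `C#CCSc1nc(NCCC#N)c2ccncc2n1` carries a 2-cyanoethyl group in that position, and in this assay compound 1 reaches only the limit of the assay, > 80000 nM. From that limit the aryl groups bring a clear gain: an at least 5.0-fold lower number from compound 1 to compound 2 (0.70 log units; beyond the scatter) and an at least 4.6-fold lower number from compound 1 to compound 3 (0.66 log units; beyond the scatter).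

Compound 4 `C#CCSc1nc(Nc2ccccc2Cl)c2ccncc2n1` is not yet measured. The change from compound 3 is 2-chlorophenyl in place of 4-fluorophenyl on a nitrogen on an aromatic ring. For the measured compounds named here, the one measured step that comes closest, a 1.1-fold higher number from compound 2 to compound 3 (0.04 log units; within the scatter), exchanged one substituent on the phenyl for another and stayed within the scatter; no measured step moves a substituent from one position on the phenyl to another. On that basis the expected step of a 1.0-fold lower number from compound 3 to compound 4 (0.01 log units; within the scatter) in this assay is small and in no firm direction. Compound 4 is therefore estimated at 17000 nM, with a likely range from 6000 nM to 50000 nM.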

Compound 4, half-maximal inhibitory concentration: > 80000 nM
Compound 4 ended at the assay's limit (the forecaster's own chance of this, stated with the estimate: 15%); middle value at least 4.7-fold (0.67 log units) away from the limit.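

Compound 2 and compound 3 suggested that an aryl group on this nitrogen was enough to improve on the 2-cyanoethyl group, and that the substituent on the phenyl mattered little in this assay; compound 4 goes against both ideas, with an at least 4.6-fold higher number from compound 3 to compound 4 (0.66 log units; beyond the scatter) and an at least 5.0-fold higher number from compound 2 to compound 4 (0.70 log units; beyond the scatter). This position therefore does respond to the choice of aryl group, and the gain seen with 4-methylphenyl and 4-fluorophenyl does not carry over to 2-chlorophenyl, even though the exchange from 4-fluorophenyl keeps the heavy-atom count the same. Compound 4 and compound 1 both rest on a limit of the assay rather than a number, so the step between them cannot be read: the limit of > 80000 nM in this assay, at which 2 of the 4 values shown sit.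

The exchange from compound 3 to compound 4 alters both the halogen and its place on the phenyl, so these compounds cannot show which of the two accounts for the step. As far as these compounds go, how an unsubstituted phenyl, or a phenyl carrying a methoxy group or an amine, would read on this nitrogen also remains open.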